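The source may report more compounds than this note shows. Statements on the series, on what has been measured and on what is new or still open speak of the compounds shown alone.

Measured compounds in an ADME assay on Vero cells (Chlorocebus sabaeus) for cytotoxicity, read by neutral red uptake, tested at 3150 ug/mL; on this read-out lower numbers stand for a stronger effect and higher numbers for a weaker effect at the one concentration tested:

Compound 1 `COc1ccc(C2SCC(=O)N2CCN2CCCCC2)cc1` gives 11%.
Compound 2 `O=C1CSC(c2ccc([N+](=O)[O-])cc2)N1CCN1CCCCC1` gives 10%.
Compound 3 `COc1ccccc1C1SCC(=O)N1CCN1CCCCC1` gives 5%.

Compound 1 and compound 2 share a core and differ by nitro in place of methoxy on an aromatic carbon; the step of a number 1 percentage points lower from compound 1 to compound 2 (within the scatter) is small. Compound 4 `O=C1CSC(c2ccccc2[N+](=O)[O-])N1CCN1CCCCC1` is not yet measured; it differs from compound 3 by nitro in place of methoxy on an aromatic carbon. This is the same kind of change as that from compound 1 to compound 2, but the place differs: there the nitro sits para to a large group, here ortho to a large group. The difference between the core of compound 3 and the core of compound 1 is not broken down here.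

Because the measured step of a number 1 percentage points lower from compound 1 to compound 2 (within the scatter) stayed within the scatter, a similarly small step no change at the digits printed from compound 3 to compound 4 (within the scatter) is expected from the same kind of change. Compound 4 is therefore estimated at about 5% in this assay, between 0% and 15%.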

Compound 4, a percentage reported as activity, at one concentration (the size of the read-out at that concentration, not a potency): 30%
Compound 4: the middle estimate sits 25 percentage points below what was measured; the measured number lies above the stated range.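

Going from methoxy to nitro, ortho to a large group, gives a number 25 percentage points higher from compound 3 to compound 4 (beyond the scatter) in this assay. The change therefore does not carry over as one fixed step between the two pairs: the same change on two cores in this assay, a number 1 percentage points lower (within the scatter) from compound 1 to compound 2 and a number 25 percentage points higher (beyond the scatter) from compound 3 to compound 4, 26 percentage points apart, beyond the scatter of two such steps

This does not show whether the core or the place of the nitro sets the size of the step, since the two pairs differ in both, and two pairs give no rule for any other core in the series.

The compounds shown leave open how the same place on the aromatic ring would respond to other groups, such as an amine or a carboxylic acid. They also leave open whether a longer chain on the ring nitrogen would alter either step.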